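A Fluorine Swap on the Ring Amine Nitrogen

The source may report more compounds than this note shows. Statements on the series, on what has been measured and on what is new or still open speak of the compounds shown alone.

Compound 2 `COc1ccccc1N1CCN(CC(=O)N(c2ccccc2)c2ccccc2)CC1` gives 50.4 mg/kg in a toxicity assay on the whole organism (strain albino) for activation, with Mus musculus as the target, with stated times of 30 min and 240 min (a lower number here means that less compound is needed, a higher number that more compound is needed for the effect), the higher of the two plain numbers. Compound 3 `O=C(CN1CCN(c2cccc(Cl)c2)CC1)N(c1ccccc1)c1ccccc1` gives 48.4 mg/kg, and the step of a 1.0-fold lower number from compound 2 to compound 3 (0.02 log units; within the scatter) changes nothing. Compound 1 `Cc1ccc(N2CCN(CC(=O)N(c3ccccc3)c3ccccc3)CC2)cc1` shows only a limit of > 40 mg/kg, so the steps a step that the limit leaves unreadable from compound 1 to compound 2 and a step that the limit leaves unreadable from compound 1 to compound 3 cannot be sized. Compound 4 `O=C(CN1CCN(c2ccc(F)cc2)CC1)N(c1ccccc1)c1ccccc1` differs from compound 2 by 4-fluorophenyl in place of 2-methoxyphenyl on an amine nitrogen in a ring. For the measured compounds named here, the one readable step, an aryl exchange at the same ring nitrogen, stayed within the scatter, so in this assay no step beyond the scatter is expected for compound 4. Compound 4 is therefore estimated at 50 mg/kg, between 30 mg/kg and 85 mg/kg. That amounts to an expected step of a 1.0-fold lower number from compound 2 to compound 4 (0.00 log units; within the scatter).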

Compound 4, dose for half-maximal effect: > 40 mg/kg
Compound 4: only a limit was reported; the forecaster's own chance of this, stated with the estimate: 30%; the middle value lies beyond the limit too.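

In this assay compound 4 gives > 40 mg/kg, a limit and not a number, and its steps to compound 1, compound 2 and compound 3 cannot be read. As far as these compounds go, whether 4-fluorophenyl matches 2-methoxyphenyl or 3-chlorophenyl on the ring nitrogen stays open.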